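Series notes: pyridyl in place of a halophenyl

A few compounds are considered here, and "the series" means these few. Any claim that something is new, unique, unknown or untested is made for them only; others in the source may bear on it.

Two compounds have numbers in a functional assay on MCF7 cells (Homo sapiens) for cytotoxicity, read by CellTiter-Glo, with a stated time of 5 days; on this read-out higher numbers stand for weaker inhibition and lower numbers for stronger inhibition. Compound 1 `CC/C(=C(/c1ccc(/C=C/C(=O)O)cc1)c1cc(C)c2[nH]ncc2c1)c1ccccc1` gives 59 nM. Compound 2 `O=C(O)/C=C/c1ccc(/C(=C(\c2ccc(F)cc2Cl)C2CCC2)c2ccc3[nH]nc(F)c3c2)cc1` gives 2 nM, the lowest of the two numbers, and its nearest neighbour is compound 1, whose number is higher by a margin beyond the scatter. For the measured compounds named here, no pair of measured compounds differs in a single place, so no single-change step is known in this assay.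

Compound 3 `O=C(O)/C=C/c1ccc(/C(=C(\c2ncc(F)cc2Cl)C2CCC2)c2ccc3[nH]nc(F)c3c2)cc1` differs from compound 2 in one place: 3-chloro-5-fluoropyridin-2-yl in place of 2-chloro-4-fluorophenyl on a double-bonded chain carbon bound to a double-bonded chain carbon and a saturated ring carbon. Going by the values given here, the series holds no measured precedent for this exchange. The change is expected to bring a step of no more than moderate size in this assay, most likely toward a somewhat higher number, and possibly none beyond the scatter. The step this expectation means is a 2.0-fold higher number from compound 2 to compound 3 (0.30 log units; within the scatter). Compound 3 is expected to give 4 nM, within a range from 1.5 nM to 12 nM.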

Compound 3, half-maximal inhibitory concentration: 1.7 nM
Beside the measured number, compound 3's estimate is 2.4-fold (0.37 log units) above it; low and high end bracket the measured number.
By their numbers in this assay, from the lowest: compounds 3 and 2 (each within the scatter of the next); then compound 1.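

Compounds 1 and 2 differ in more than one place, so they gave no reading of the aryl group on a double-bonded chain carbon bound to a double-bonded chain carbon and a saturated ring carbon. In this assay, for the compounds shown here, 3-chloro-5-fluoropyridin-2-yl in place of 2-chloro-4-fluorophenyl gives a 1.2-fold lower number from compound 2 to compound 3 (0.07 log units; within the scatter), so this exchange, which brings a ring hetero atom and a hydrogen-bond acceptor, leaves no step that can be told from the scatter. This single exchange at a single position supports no wider rule for the series.

Going by these compounds, whether a pyrimidin-2-yl ring or a 3-chloropyridin-2-yl group without the fluorine would hold the number at this position stays open. No supporting measurement bears on why compound 2 and compound 3 read alike.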